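Losing One Chloro on a Fused Dichloro Core

The source may hold more compounds than are shown below. What is called first, only, known or untested is meant among the compounds shown, and "the series" means these compounds.

Among the compounds with values here, compound 2 `ClCc1ccccc1Cn1cnc2c(Cl)nc(Cl)nc21` gives 350 nM in a functional assay on HOP-92 cells (Homo sapiens) for cytotoxicity, read by sulforhodamine B assay, with a stated time of 48 h (a higher number here means a weaker inhibitor of growth, a lower number a stronger inhibitor of growth), the lowest of the two numbers measured so far. Compound 1 `ClCc1ccc(Cn2cnc3c(Cl)ncnc32)cc1` differs from compound 2 at several places; in this assay compound 1 gives 6020 nM. Compound 3 `ClCc1ccccc1Cn1cnc2c(Cl)ncnc21` has not yet been tested; the change from compound 2 is hydrogen in place of chloro on an aromatic carbon. Within the data shown here, with no single-change step measured here, the direction is uncertain, but the weaker number of compound 1, 6020 nM, suggests a move toward weaker growth inhibition. Compound 3 is estimated at 1500 nM in this assay, within 400 nM to 6000 nM. That step, a 4.3-fold higher number from compound 2 to compound 3 (0.63 log units; beyond the scatter), is expected to exceed the scatter.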

Compound 3, concentration for 50% growth inhibition: 1480 nM
Estimate against measurement, compound 3: 1.0-fold (0.01 log units) above; low and high end bracket the measured number.
By their numbers in this assay, from the lowest: compound 2; then compound 3; then compound 1.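

In this assay, the chloro on the aromatic carbon between two ring nitrogen atoms now has a single-change step of its own: with hydrogen in its place, the result is a 4.2-fold higher number from compound 2 to compound 3 (0.63 log units; beyond the scatter). Growth inhibition is therefore weaker without chloro at this position, although compound 3 keeps some activity. Nothing available explains this loss. As far as these compounds go, it remains open whether an amine or a methoxy group on this same carbon would match chloro or fall short of it. From the compounds shown here alone, the effect of a single change at the remaining chloro also stays open.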